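The source may report more compounds than this note shows. Statements on the series, on what has been measured and on what is new or still open speak of the compounds shown alone.

- Compound 1 `CNc1nc(-c2cc(OC)c(OC)c(OC)c2)c(-c2ccc(C)cc2)s1`: 69.1 nM
- Compound 2 `COc1cc(-c2nc(N(C)C)sc2-c2ccc(C)cc2)cc(OC)c1OC`: 4140 nM

Both numbers come from a functional assay on HeLa cells (Homo sapiens) for antiproliferative activity, read by MTT assay, with a stated time of 72 h; a lower number here means a stronger inhibitor, a higher number a weaker inhibitor. Going by the values given here, of the two compounds measured so far, compound 2 has the higher number and is therefore the weaker inhibitor. Compound 3 `COc1cc(-c2nc(C)sc2-c2ccc(C)cc2)cc(OC)c1OC` differs from compound 2 in one place, with methyl in place of dimethylamino on an aromatic carbon.

Among the compounds with values here, only one measured step touches this group: a 60-fold higher number from compound 1 to compound 2 (1.78 log units; beyond the scatter). That step, methyl in place of hydrogen on a nitrogen on an aromatic ring, is large and lies beyond the scatter. It shows that a small edit here can move the number a long way, but it involves no methyl placed directly on the aromatic carbon, so it offers only indirect guidance. A move to a lower number is expected, smaller in size than the step seen between the two measured compounds, and the uncertainty is wide. The expected step is a 5.2-fold lower number from compound 2 to compound 3 (0.71 log units; beyond the scatter). For compound 3 the estimated value is 800 nM, with an expected range from 120 nM to 5000 nM.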

Compound 3, half-maximal inhibitory concentration: 1100 nM
Compound 3: the middle estimate sits 1.4-fold (0.14 log units) below what was measured; the measured number falls inside the stated range.
By their numbers in this assay, from the lowest: compound 1; then compound 3; then compound 2.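

Going by these compounds alone, the single methyl group on this carbon, next to the ring nitrogen and the ring sulfur, carries no nitrogen, yet in this assay it does not fall to the bottom of the series: replacing dimethylamino with methyl gives a 3.8-fold lower number from compound 2 to compound 3 (0.58 log units; beyond the scatter) and still leaves a clear distance from the methylamino compound, as replacing methylamino with methyl gives a 16-fold higher number from compound 1 to compound 3 (1.20 log units; beyond the scatter) in this same measure. The two nitrogen-bearing groups therefore do not sit together, with methyl ranking on the far side of one and the near side of the other, so having a nitrogen on this carbon does not by itself set the number across these three compounds. The data shown offer no measurement that accounts for this order.

A plain amino group, an ethylamino group or a methoxy group on the same carbon would show whether the trend among these substituents extends beyond the three compared here. On these data alone, whether the same order holds when the 4-methylphenyl group or the rest of the shared core is changed also remains open.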